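Adding Chlorine Next to the Ring Nitrogen

A few compounds are considered here, and "the series" means these few. Any claim that something is new, unique, unknown or untested is made for them only; others in the source may bear on it.

Of the compounds shown here, three sharing a cyclic urea core have been tested in an assay on RBL-1 cells for inhibition of Polyunsaturated fatty acid 5-lipoxygenase (Rattus norvegicus); a higher number here means a weaker inhibitor, a lower number a stronger inhibitor. Compound 1 `COc1cccc(N2CCNC(=O)N2)c1` gives 47000 nM, compound 2 `O=C1NCCN(c2ccccn2)N1` gives 26000 nM, and compound 3 `Cc1cccc(N2CC(C)NC(=O)N2)n1` gives 3800 nM. Compound 2 thus stands second highest of the three numbers: its value and that of compound 1 lie within the usual scatter of each other, so the two cannot be ordered, while compound 3 sits clearly lower, beyond the scatter.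

Compound 4 `O=C1NCCN(c2cccc(Cl)n2)N1` has not yet been measured. It differs from compound 2 by chloro in place of hydrogen on an aromatic carbon, on an aromatic carbon of a six-membered aromatic ring with 1 nitrogen, next to the ring nitrogen. For the measured compounds named here, no measured pair shows this exact change, so the effect in this assay is uncertain. Compound 3 carries a methyl at that same kind of position and gives 3800 nM, which hints that a small group there may be tolerated or helpful. A modest step toward a lower number is therefore expected, a 2.2-fold lower number from compound 2 to compound 4 (0.34 log units; beyond the scatter), though it could fall within the scatter. The value expected for compound 4 is 12000 nM, with a range from 4000 nM to 40000 nM.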

Compound 4, half-maximal inhibitory concentration: 5600 nM
The estimate for compound 4 lay 2.1-fold (0.33 log units) above the measured number; measured number inside the range.
By their numbers in this assay, from the lowest: compounds 3 and 4 (each within the scatter of the next); then compounds 2 and 1 (each within the scatter of the next).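

In this assay, chloro in place of hydrogen on an aromatic carbon, next to the ring nitrogen, gives a 4.6-fold lower number from compound 2 to compound 4 (0.67 log units; beyond the scatter). For the compounds shown here, this is the first direct reading of a change at this position, as no earlier pair differed in one place only, and it shows that a single chlorine atom here lowers the number by a modest step that lies beyond the scatter. Nothing available explains why this substitution has that effect.

The compounds shown do not tell whether the step is particular to chloro or whether a fluoro, a bromo or an amine at this same place would give a similar result. They also leave open whether chloro would have a comparable effect on another aromatic carbon of this ring.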